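The compounds below may be only part of what the source reports. "The series", "measured", "known", "first", "only" and "open" are said of these compounds alone.

Compound 2 `Cc1ccc(-c2cc(-c3ccc(Cl)o3)cc(-c3ccsc3)n2)o1` in a functional assay on HeLa cells (Homo sapiens) for cytotoxicity, in the presence of a further agent that is not named here (on this read-out higher numbers stand for weaker inhibition and lower numbers for stronger inhibition), gives > 50000 nM, which is a limit of the assay and not a number. Compound 1 `Clc1ccc(-c2cc(-c3cccnc3)nc(-c3ccsc3)c2)o1` in this assay gives > 50000 nM, likewise a limit. Among the measured compounds shown here, the one measured step, a step that the two limits leave unreadable from compound 1 to compound 2, therefore cannot be read, since both values sit at the limit of > 50000 nM in this assay, at which 2 of the 2 values shown sit. Compound 3 `Clc1ccc(-c2cc(-c3ccsc3)nc(-c3ccccn3)c2)o1` differs from compound 2 by pyridin-2-yl in place of 5-methylfuran-2-yl on an aromatic carbon. For the measured compounds named here, no measured step bears on this change, and the two limits give no size to work from. The step that the limit leaves unreadable from compound 2 to compound 3 is expected to be nothing readable. The estimate for compound 3 is 60000 nM, within 20000 nM to 200000 nM, most likely again reported as a limit.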

Compound 3, half-maximal inhibitory concentration: 22500 nM
Compound 3: middle estimate off by 2.7-fold (0.43 log units), on the high side; measured number inside the range.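

In this assay, the position next to the ring nitrogen now gives a readable change: pyridin-2-yl in place of 5-methylfuran-2-yl is an at least 2.2-fold lower number from compound 2 to compound 3 (0.34 log units; beyond the scatter). Among the two pyridines at this position, pyridin-2-yl in place of pyridin-3-yl is an at least 2.2-fold lower number from compound 1 to compound 3 (0.34 log units; beyond the scatter), so the attachment of the pyridine matters here and not only its presence. Both sizes are lower bounds, and the step between the two compounds held at the limit cannot be read: the limit of > 50000 nM in this assay, at which 2 of the 3 values shown sit.

On these data alone, whether pyridin-2-yl is the best group at this position stays open. An amine or a carboxylic acid here remains untested in the compounds shown.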